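This account rests on a few compounds, and the source may have more. Where it says the series, first, only, none or still open, it means among the compounds named here.

In a functional assay on HT-29 cells (Homo sapiens) for inhibition, read by sulforhodamine B assay (on this read-out lower numbers stand for stronger inhibition and higher numbers for weaker inhibition), compound 1 `COC(=O)CC/C(C)=C/Cc1c(OC)c(C)c2c(c1OCC#CCN1CCN(c3ccccc3F)CC1)C(=O)OC2` gives > 50000 nM, which is a limit and not a number. Compound 3 `COC(=O)CC/C(C)=C/Cc1c(OC)c(C)c2c(c1OCC#CCN1CCC(C(=O)OC)CC1)C(=O)OC2` gives > 50000 nM, also a limit. Compound 2 `CCCCNc1ccc(CC#CCOc2c(C/C=C(\C)CCC(=O)OC)c(OC)c(C)c3c2C(=O)OC3)cc1` gives 36700 nM. The readings therefore crowd against (the limit of > 50000 nM in this assay, at which 2 of the 3 values shown sit).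

Compound 4 `COC(=O)CC/C(C)=C/Cc1c(OC)c(C)c2c(c1OCC#CCN1CCN(C(=O)C3COc4ccccc4O3)CC1)C(=O)OC2` has (2,3-dihydro-1,4-benzodioxin-2-yl)carbonyl in place of 2-fluorophenyl on an amine nitrogen in a ring of compound 1: (2,3-dihydro-1,4-benzodioxin-2-yl)carbonyl in place of 2-fluorophenyl on an amine nitrogen in a ring. For the measured compounds named here, no measured step makes this exchange. Only an at least 1.3-fold higher number from compound 2 to compound 3 (0.13 log units; that floor lies within the scatter) bears on it loosely, as a change at the end of the same side chain, and it stays within the scatter. No step beyond the scatter is therefore expected in this assay. The estimated step is an at least 1.1-fold lower number from compound 1 to compound 4 (0.04 log units; that floor lies within the scatter). Compound 4 is expected at 45000 nM, with an estimated range of 22000 nM to 50000 nM.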

Compound 4, half-maximal inhibitory concentration: > 50000 nM
Compound 4 gave a limit, no number; the forecaster's own chance of this, stated with the estimate: 65%; at least 1.1-fold (0.04 log units) between middle value and limit.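

Compound 1 and compound 4 both give a limit and not a number, so the step between them cannot be read: the limit of > 50000 nM in this assay, at which 3 of the 4 values shown sit.

The compounds shown leave open how far (2,3-dihydro-1,4-benzodioxin-2-yl)carbonyl and 2-fluorophenyl on an amine nitrogen in a ring differ in inhibition.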